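Shifting a Pyridine Nitrogen: From Compound 2 to Compound 4

This account rests on a few compounds, and the source may have more. Where it says the series, first, only, none or still open, it means among the compounds named here.

Of the compounds shown here, three have been tested in a functional assay with Rattus norvegicus as the target; a higher number here means a weaker inhibitor, a lower number a stronger inhibitor. Compound 1 `CC(C)(C)c1ccc(C(=O)/C=C/c2ccncc2)cc1` gives 47000 nM. Compound 2 `COc1cc(C(=O)/C=C/c2cccnc2)cc(OC)c1OC` gives 30000 nM, and compound 3 `O=C(c1ccccc1)c1cccc(-c2cccnc2)c1` gives about 100000 nM. Compound 2 sits at the low end of these three numbers; its gap to compound 1 lies within the usual scatter, while its gap to compound 3 lies beyond it. Compound 4 `COc1cc(C(=O)/C=C/c2ccccn2)cc(OC)c1OC` has not yet been measured. It differs from compound 2 in one place: pyridin-2-yl in place of pyridin-3-yl on a double-bonded chain carbon bound to a double-bonded chain carbon. No measured pair shows what this change does here, so nothing in the numbers shown points to a direction. A step no larger than the scatter is expected, and no change at the digits printed from compound 2 to compound 4 (within the scatter) is the expected step. Compound 4 is estimated at 30000 nM, with a range from 10000 nM to 100000 nM.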

Compound 4, half-maximal inhibitory concentration: 18000 nM
Compound 4: the middle estimate sits 1.7-fold (0.22 log units) above what was measured; measured number inside the range.
By their numbers in this assay, from the lowest: compounds 4, 2 and 1 (each within the scatter of the next, the first and the last beyond it); then compound 3.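

Swapping pyridin-3-yl for pyridin-2-yl on this chain gives a 1.7-fold lower number from compound 2 to compound 4 (0.22 log units; within the scatter), so this pair offers the first direct reading of the change. The shift of the ring nitrogen leaves the number within the scatter, and the two groups cannot be told apart here. No supporting data bear on this result.

Still open, as far as these compounds go, is how pyridin-4-yl would read on the core of compound 2. It is also unknown whether an amine or a carboxylic acid on the pyridine ring would produce a step beyond the scatter.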